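The source may hold more compounds than are shown below. What is called first, only, known or untested is meant among the compounds shown, and "the series" means these compounds.

Among the compounds with values here, compound 1 `O=C(O)CCCSCCN1C(=O)SC[C@@H]1/C=C/[C@@H](O)Cc1ccccc1` is one of two compounds measured in an assay on CHO cells for displacement of a labelled ligand from prostaglandin E2 receptor EP4 subtype (Mus musculus), read by scintillation counting, with a stated time of 60 min; a higher number here means a weaker inhibitor, a lower number a stronger inhibitor. In this assay compound 1 gives 0.65 nM, the higher of the two numbers recorded so far. The other compound, compound 2 `Cc1cccc(C[C@H](O)/C=C/[C@H]2CCC(=S)N2CCSCCCC(=O)O)c1`, gives 0.5 nM in this assay, and the gap between compound 1 and compound 2 lies within the scatter of repeated measurements, so neither stands apart from the other.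

Compound 3 `COCc1cccc(C[C@H](O)/C=C/[C@H]2CSC(=O)N2CCSCCCC(=O)O)c1` has not yet been measured. It differs from compound 1 by a single change: methoxymethyl in place of hydrogen on an aromatic carbon. Within the data shown here, no step of this kind has been measured. The expected step of a 1.1-fold higher number from compound 1 to compound 3 (0.03 log units; within the scatter) is none beyond the scatter, because compound 2 at 0.5 nM shows that this part of the molecule tolerates a small added group without a clear shift. Compound 3 is therefore estimated at 0.7 nM, with a range from 0.25 nM to 2 nM.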

Compound 3, inhibition constant: 1.2 nM
Compound 3: middle estimate off by 1.7-fold (0.23 log units), on the low side; measured number inside the range.
By their numbers in this assay, from the lowest: compounds 2, 1 and 3 (each within the scatter of the next, the first and the last beyond it).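

Adding methoxymethyl to an aromatic carbon of the phenyl ring, meta to a large group, gives a 1.8-fold higher number from compound 1 to compound 3 (0.27 log units; within the scatter) in this assay and is the only single-change step measured in this series. Compound 3 therefore shows that this ring carbon can carry a group of this size, one that includes an oxygen atom, and still stay within the scatter of compound 1 in this binding measurement. No measured evidence bears on why the step is this size.

A single step leaves open whether other groups at this ring carbon, such as an amine, a carboxylic acid or a longer chain, would also stay within the scatter. It also leaves open whether the oxygen atom matters, which a propyl group in place of methoxymethyl could test.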